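The compounds below may be only part of what the source reports. "The series", "measured", "known", "first", "only" and "open" are said of these compounds alone.

Measured so far in an in vitro functional assay on cells for agonist activity at Bombesin receptor subtype-3 (Homo sapiens), read by luminescence and calcium flux; a higher number here means that more compound is needed for the effect, a lower number that less compound is needed:
- compound 1 `O=C(O)c1ccccc1-c1ccc(CCc2ncc(Cc3ccccc3Cl)[nH]2)cc1` gives 292 nM
- compound 2 `O=C(O)c1ccccc1-c1ccc(CCc2ncc(Cc3ccc(Cl)cc3)[nH]2)cc1` gives 2290 nM
- compound 3 `O=C(O)c1ccccc1-c1ccc(CCc2ncc(-c3ccccc3)[nH]2)cc1` gives 4950 nM

Compound 3 carries the highest number of the three; both a 17-fold higher number from compound 1 to compound 3 (1.23 log units; beyond the scatter) and a 2.2-fold higher number from compound 2 to compound 3 (0.33 log units; beyond the scatter) run upward and beyond the scatter. Compound 4 `N#Cc1ccccc1Cc1cnc(CCc2ccc(-c3ccccc3C(=O)O)cc2)[nH]1` differs from compound 3 by 2-cyanobenzyl in place of phenyl on an aromatic carbon. The step that bears most directly is a 17-fold higher number from compound 1 to compound 3 (1.23 log units; beyond the scatter), where 2-chlorobenzyl rather than phenyl on that aromatic carbon went with a far lower number; a 2.2-fold higher number from compound 2 to compound 3 (0.33 log units; beyond the scatter) shows a smaller difference of the same sign for 4-chlorobenzyl. No benzyl bearing a nitrile has been measured in this series, so the size is read from compound 1 alone. A clear decrease is expected, an 11-fold lower number from compound 3 to compound 4 (1.04 log units; beyond the scatter). Compound 4 is estimated at 450 nM, with a range of 150 nM to 1500 nM.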

Compound 4, half-maximal effective concentration: 5480 nM
The estimate for compound 4 lay 12-fold (1.09 log units) below the measured number; the measured number lies above the stated range.
By their numbers in this assay, from the lowest: compound 1; then compound 2; then compounds 3 and 4 (each within the scatter of the next).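

In this assay, the step of a 1.1-fold higher number from compound 3 to compound 4 (0.04 log units; within the scatter) with 2-cyanobenzyl in place of phenyl shows that a benzyl on this aromatic carbon does not by itself go with a lower number. The substituent on the benzyl matters: cyano in place of chloro gives a 19-fold higher number from compound 1 to compound 4 (1.27 log units; beyond the scatter) and only the 2-chloro compound stands well apart, while the step of a 2.4-fold higher number from compound 2 to compound 4 (0.38 log units; beyond the scatter) is modest. Nothing available explains this difference between chloro and cyano. From the compounds shown here alone, whether plain benzyl, or methyl or fluoro in place of the nitrile, stands with compound 1 or with compound 4 stays open.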